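Working notes: chloro for fluoro on the nitrophenyl series

The source may report more compounds than this note shows. Statements on the series, on what has been measured and on what is new or still open speak of the compounds shown alone.

Values in a functional assay on HepG2 cells (Homo sapiens) for cytotoxicity, read by MTT assay, with a stated time of 24 h (on this read-out lower numbers stand for stronger inhibition and higher numbers for weaker inhibition), follow.
- Compound 1 `COc1ccc(/C=C2\CN(C)C/C(=C\c3ccccc3F)C2=O)cc1` gives 12300 nM
- Compound 2 `CN1C/C(=C\c2cccc([N+](=O)[O-])c2)C(=O)/C(=C/c2ccccc2F)C1` gives 1080 nM
- Compound 3 `CN1C/C(=C\c2ccc(F)cc2)C(=O)/C(=C/c2cccc([N+](=O)[O-])c2)C1` gives 9340 nM

Compound 3 lies within the scatter of compound 1, and both values sit well above that of compound 2 (1080 nM). Compound 4 `CN1C/C(=C\c2ccc(Cl)cc2)C(=O)/C(=C/c2cccc([N+](=O)[O-])c2)C1` differs from compound 3 by one change (chloro in place of fluoro on an aromatic carbon), namely chloro in place of fluoro on an aromatic carbon, para to a large group.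

Among the compounds with values here, the only measured step that bears on this group is an 8.6-fold higher number from compound 2 to compound 3 (0.94 log units; beyond the scatter) and it lies beyond the scatter. That step, however, exchanges 2-fluorophenyl for 4-fluorophenyl, so it gives no direct reading on chloro replacing fluoro. Within the data shown here, no measured pair exchanges one halogen for another. The 4-fluorophenyl to 4-chlorophenyl change is therefore expected to produce no step beyond the scatter, and the data indicate no firm direction. The estimate means a 1.2-fold lower number from compound 3 to compound 4 (0.07 log units; within the scatter) in this assay as an expected step within the scatter. Compound 4 is expected at 8000 nM with an estimated range from 3500 nM to 18000 nM in this assay as its likely span.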

Compound 4, half-maximal inhibitory concentration: 8210 nM
Estimate against measurement, compound 4: 1.0-fold (0.01 log units) below; the range from low to high includes it.
By their numbers in this assay, from the lowest: compound 2; then compounds 4, 3 and 1 (each within the scatter of the next).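

Chloro in place of fluoro on an aromatic carbon, para to a large group, gives the first direct halogen-for-halogen reading in the series: in this assay the step is a 1.1-fold lower number from compound 3 to compound 4 (0.06 log units; within the scatter), so these two halogens are not told apart at this position. The gap to compound 2 also holds with either halogen, since 4-chlorophenyl in place of 2-fluorophenyl gives a 7.6-fold higher number from compound 2 to compound 4 (0.88 log units; beyond the scatter), much as 4-fluorophenyl in place of 2-fluorophenyl gave an 8.6-fold higher number from compound 2 to compound 3 (0.94 log units; beyond the scatter), which means that the earlier step is not peculiar to fluoro at this position. Nothing in the available data accounts for this result.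

The compounds shown leave open whether this aromatic carbon accepts anything other than a halogen, such as an amine or a carboxylic acid, while the value stays in the range of compound 3 and compound 4. Also open, from the compounds shown here alone, is whether the same exchange of chloro for fluoro stays within the scatter on the fluorophenyl ring of compound 2, which gives 1080 nM and so starts from a much lower number.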